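The source may report more compounds than this note shows. Statements on the series, on what has been measured and on what is new or still open speak of the compounds shown alone.

In an assay for inhibition of Fatty-acid amide hydrolase 1 (Rattus norvegicus) (a lower number here means a stronger inhibitor, a higher number a weaker inhibitor), three compounds of the same core have been measured. Compound 1 `COC(=O)c1cnc(C(=O)CCc2ccc(Oc3ccccc3)cc2)o1` gives 1.7 nM, compound 2 `N#Cc1cnc(C(=O)CCc2ccc(Oc3ccccc3)cc2)o1` gives 0.8 nM, and compound 3 `COC(=O)c1ccc(-c2cnc(C(=O)CCc3ccc(Oc4ccccc4)cc3)o2)nc1` gives 54 nM. Compound 3 therefore stands highest of the three numbers and is the weakest inhibitor of the set, since both of its steps to the others lie beyond the scatter.

The next compound, compound 4 `O=C(CCc1ccc(Oc2ccccc2)cc1)c1ncc(C(F)(F)F)o1`, differs from compound 3 in one place: trifluoromethyl in place of 5-(methoxycarbonyl)pyridin-2-yl on an aromatic carbon. Going by the values given here, two measured steps bear on this. Going from compound 1 to compound 3, the change was a 32-fold higher number from compound 1 to compound 3 (1.50 log units; beyond the scatter), and going from compound 2 to compound 3 it was a 68-fold higher number from compound 2 to compound 3 (1.83 log units; beyond the scatter). In both cases putting the larger group onto this carbon of the core raised the number by a large amount, while the two small groups in compound 1 and compound 2 gave low numbers. Replacing the large group with a small trifluoromethyl group should therefore undo most of that rise, and the expected step is a 27-fold lower number from compound 3 to compound 4 (1.43 log units; beyond the scatter), a large drop in this assay. The estimated value for compound 4 is 2 nM, with a range from 0.5 nM to 10 nM.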

Compound 4, inhibition constant: 2 nM
Compound 4: middle estimate and measured number agree at the digits printed, and the stated range covers the measured number.
By their numbers in this assay, from the lowest: compound 2; then compounds 1 and 4 (each within the scatter of the next); then compound 3.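

Taking away the 5-(methoxycarbonyl)pyridin-2-yl group gives a 27-fold lower number from compound 3 to compound 4 (1.43 log units; beyond the scatter), which ties the high number of compound 3 to that group and shows that trifluoromethyl, with no ring and no hydrogen-bond acceptors, is enough on this carbon for a low number. Trifluoromethyl and methoxycarbonyl cannot be told apart here, with a 1.2-fold higher number from compound 1 to compound 4 (0.07 log units; within the scatter), whereas the nitrile keeps a modest edge, with a 2.5-fold higher number from compound 2 to compound 4 (0.40 log units; beyond the scatter), so compound 2 remains the strongest inhibitor of the four. Nothing measured here explains why these groups differ.

Compound 3 brings in a ring and a methoxycarbonyl together, so a plain pyridin-2-yl or phenyl group on this carbon would be needed to show which part goes with the higher number. The compounds shown also leave open how this position responds to an amine, a carboxylic acid or a longer chain, since every group so far either is small or carries a six-membered aromatic ring.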